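Swapping the Imidazole on the Sulfur for a Carboxypyridine

The source may hold more compounds than are shown below. What is called first, only, known or untested is meant among the compounds shown, and "the series" means these compounds.

Of the compounds shown here, three sharing a benzothiazole-amide core have been tested in a functional assay on HCT-116 cells (Homo sapiens) for antiproliferative activity, read by MTT assay, with a stated time of 72 h; a higher number here means a weaker inhibitor, a lower number a stronger inhibitor. Compound 1 `Cc1cc(C)cc(C(=O)Nc2nc3ccc(NC(=O)CSc4ccc(Cl)cc4)cc3s2)c1` gives 65100 nM, compound 3 `O=C(CSc1cccc(O)c1)Nc1ccc2nc(NC(=O)c3ccccc3)sc2c1` gives 41000 nM, and compound 2 `O=C(CSc1ncc[nH]1)Nc1ccc2nc(NC(=O)c3ccc(C(F)(F)F)cc3)sc2c1` gives 2690 nM. Compound 2 therefore stands lowest of the three numbers: its nearest neighbour is compound 3, whose number is higher by a margin beyond the scatter, and compound 1 lies further still, also beyond the scatter. Compound 2 is thus the strongest inhibitor among the measured compounds.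

Compound 4 `O=C(CSc1ncccc1C(=O)O)Nc1ccc2nc(NC(=O)c3ccc(C(F)(F)F)cc3)sc2c1` is not yet measured. It differs from compound 2 in one place, on the sulfur whose other neighbour is a saturated chain carbon: 3-carboxypyridin-2-yl in place of 1H-imidazol-2-yl on a sulfur. Going by the values given here, no measured pair shows this same exchange, so its effect cannot be read from a recorded step; the only guide is that the weaker compounds 1 and 3 carry six-membered aromatic rings on that sulfur, while they also differ from compound 2 elsewhere. Compound 4 is expected to lose some ground against compound 2, with an estimated step of a 3.3-fold higher number from compound 2 to compound 4 (0.52 log units; beyond the scatter). The expected value for compound 4 in this assay is 9000 nM, within a range of 2500 nM to 35000 nM.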

Compound 4, half-maximal inhibitory concentration: 2300 nM
For compound 4 the middle estimate is 3.9-fold (0.59 log units) above the measured one; measured number below the stated range.
By their numbers in this assay, from the lowest: compounds 4 and 2 (each within the scatter of the next); then compounds 3 and 1 (each within the scatter of the next).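

In this assay the exchange of 1H-imidazol-2-yl for 3-carboxypyridin-2-yl on the sulfur gives a 1.2-fold lower number from compound 2 to compound 4 (0.07 log units; within the scatter) and so leaves the two compounds indistinguishable in this read-out. This is the first pair shown that differs in one place only, and it isolates what compounds 1 and 3 could not, as they also differ from compound 2 elsewhere: at this sulfur, whose other neighbour is a saturated chain carbon, a five-membered aromatic ring of 5 heavy atoms and a six-membered aromatic ring group of 9 heavy atoms read alike. The data offer no measurement that would account for this equivalence.

It remains open whether the pyridine ring or the carboxylic acid matters more here, since the compounds shown include no plain pyridin-2-yl group, and no methyl ester or primary amide in place of the acid. It also remains open whether the same exchange would read alike with the other acyl groups seen in compound 1 and compound 3, as it is shown only with the acyl group shared by compound 2 and compound 4.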